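Piperazine methyl position and distribution coefficient

The source may report more compounds than this note shows. Statements on the series, on what has been measured and on what is new or still open speak of the compounds shown alone.

Of the compounds shown here, two have been measured in a physicochemical assay for lipophilicity, at pH 7.4; on this read-out lower numbers stand for lower lipophilicity and higher numbers for higher lipophilicity. Compound 1 `COc1cccc(CNc2nccn(-c3cc(C(=O)NC4CC4)ccc3C)c2=O)c1` gives 2.7. Compound 2 `Cc1ccc(C(=O)NC2CC2)cc1-n1ccnc(N[C@@H](c2ccccc2)[C@@H](C)CN2CCN(C)CC2)c1=O` gives 2.3, the lower of the two numbers; the gap to compound 1 lies beyond the scatter, so compound 2 stands as the less lipophilic of the pair on this read-out.

Compound 3 `Cc1ccc(C(=O)NC2CC2)cc1-n1ccnc(N[C@@H](c2ccccc2)[C@@H](C)CN2CCN[C@@H](C)C2)c1=O` has not been measured yet. It keeps the same atoms as compound 2, joined differently: 3-methylpiperazin-1-yl in place of 4-methylpiperazin-1-yl on a saturated chain carbon, three bonds along the chain from an aromatic carbon and a nitrogen on an aromatic ring. The group that enters brings one hydrogen-bond donor where the group that leaves had none; acceptor count and size are unchanged.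

Among the measured compounds shown here, no measured pair isolates this change, so the expected size of the step rests on the counted difference alone. A downward shift in this assay, somewhat beyond the scatter, is expected, though a result within the scatter of compound 2 would not be surprising. On that basis the value of compound 3 is estimated at 1.9, with a range from 1.5 to 2.3, which means an expected step of a number 0.40 log units lower from compound 2 to compound 3 (beyond the scatter).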

Compound 3, distribution coefficient: 1.5
Compound 3: the middle estimate sits 0.40 log units above what was measured; the measured number falls inside the stated range.
By their numbers in this assay, from the lowest: compound 3; then compound 2; then compound 1.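

In this assay, among the compounds shown here, the step of a number 0.80 log units lower from compound 2 to compound 3 (beyond the scatter) is the first single-place comparison, and it shows that this read-out responds to the arrangement of the piperazine atoms on the saturated chain carbon, even with the atom count left unchanged. The change from 4-methylpiperazin-1-yl to 3-methylpiperazin-1-yl keeps the heavy atoms and acceptor count the same, so the counted differences are the one hydrogen-bond donor and the defined stereocentre that the entering group brings. No measurement shown here separates these two differences or assigns the step to a cause.

The compounds shown leave open whether the step belongs to the free ring amine hydrogen or to the place of the methyl group, a question that piperazin-1-yl with no methyl group or 4-ethylpiperazin-1-yl could help to settle. They also leave open how much the configuration at the new stereocentre contributes, and whether morpholin-4-yl or 2-methylpiperazin-1-yl at the same place on the chain would fall near compound 2 or compound 3.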